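A few compounds are considered here, and "the series" means these few. Any claim that something is new, unique, unknown or untested is made for them only; others in the source may bear on it.

Three compounds share one core and differ only in the group on a saturated chain carbon bound to an oxygen on a saturated carbon. In a functional assay on HEK293 cells for agonist activity at G-protein coupled receptor 39 (Homo sapiens), read by scintillation proximity assay and inositol phosphate accumulation, with a stated time of 75 min, in the presence of a further agent that is not named here (on this read-out lower numbers stand for an effect already at smaller amounts and higher numbers for an effect only at larger amounts of compound), compound 1 `Cc1nn(-c2ncnc3nc[nH]c23)c2c1C(OCc1ccccc1C#N)CC(=O)N2` gives 8 nM, compound 2 `Cc1nn(-c2ncnc3nc[nH]c23)c2c1C(OCCn1nccc1C)CC(=O)N2` gives 10 nM, and compound 3 `Cc1nn(-c2ncnc3nc[nH]c23)c2c1C(OCc1ccc(F)cc1)CC(=O)N2` gives 1 nM, the lowest of the three, as the steps of an 8.0-fold lower number from compound 1 to compound 3 (0.90 log units; beyond the scatter) and a 10-fold lower number from compound 2 to compound 3 (1.00 log units; beyond the scatter) show. Compound 4 `Cc1nn(-c2ncnc3nc[nH]c23)c2c1C(OCC(C)C)CC(=O)N2` carries the change (isopropyl in place of 4-fluorophenyl on a saturated chain carbon bound to an oxygen on a saturated carbon). Among the measured compounds shown here, no measured step trades the ring for a group without a ring, so the two steps into compound 3 only show that 4-fluorophenyl gave the lowest number so far; removing it is expected to raise the number modestly, a 15-fold higher number from compound 3 to compound 4 (1.18 log units; beyond the scatter). Compound 4 is therefore estimated at 15 nM, within 4 nM to 60 nM.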

Compound 4, half-maximal effective concentration: 4 nM
Estimate against measurement, compound 4: 3.8-fold (0.57 log units) above, and the stated range covers the measured number.
By their numbers in this assay, from the lowest: compound 3; then compounds 4, 1 and 2 (each within the scatter of the next, the first and the last beyond it).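

Among the compounds shown here, a group with no ring can sit at this position: isopropyl gives a 4.0-fold higher number from compound 3 to compound 4 (0.60 log units; beyond the scatter) in this assay, so the ring of 4-fluorophenyl is not needed for a number this low, even though it gives the lowest number so far. Against the other two groups, isopropyl gives a 2.5-fold lower number from compound 2 to compound 4 (0.40 log units; beyond the scatter), while a 2.0-fold lower number from compound 1 to compound 4 (0.30 log units; within the scatter) does not separate those two compounds. Nothing measured here explains these steps. Still open, from the compounds shown here alone, is how an unsubstituted phenyl, a longer chain or an amine would read at this position.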